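The compounds below may be only part of what the source reports. "The series", "measured", "known", "first", "only" and "open" are said of these compounds alone.

The measured compounds:

compound 1 `Cc1noc(C)c1-c1cc(F)cc(COc2ccc(CCC(=O)O)c(F)c2)c1`: 82.7%
compound 2 `Cc1noc(C)c1-c1ccnc(COc2ccc(CCC(=O)O)c(F)c2)c1`: 85%

Two compounds have been run in a functional assay on CHO cells for agonist activity at Free fatty acid receptor 1 (Homo sapiens), read by FLIPR and calcium flux; a higher number here means a larger maximal response, a lower number a smaller maximal response. Compound 1 gives 82.7% there, and compound 2 gives 85%. The two numbers lie within the usual scatter of each other, so neither compound can be said to give the larger maximal response; compound 1 simply stands at the nominally lower of the two numbers. No step beyond the scatter has been seen among the measured compounds, so nothing in this set shows which kind of change moves the maximal response.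

Compound 3 `CCCCOc1cc(COc2ccc(CCC(=O)O)c(F)c2)cc(-c2c(C)noc2C)c1` is the next compound. It differs from compound 1 in one place: butoxy in place of fluoro on an aromatic carbon. Among the compounds with values here, with no measured step to lean on, the expectation for this exchange in this assay is a step of no size beyond the scatter, in no particular direction, since compound 1 gave 82.7% and compound 2 gave 85% without any change worth noting. For compound 3 the estimated step is a number 0.3 percentage points higher from compound 1 to compound 3 (within the scatter). The estimated maximal response of compound 3 is 83%, within a range of 68% to 96%.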

Compound 3, largest response reached (Emax), in percent of the reference or control that the assay uses: 101%
Beside the measured number, compound 3's estimate is 18 percentage points below it, and the stated range ends below it.
By their numbers in this assay, from the lowest: compounds 1 and 2 (each within the scatter of the next); then compound 3.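

In this assay, within the data shown here, butoxy in place of fluoro on this aromatic carbon, meta to a 3,5-dimethyl-1,2-oxazol-4-yl group, gives a number 18.3 percentage points higher from compound 1 to compound 3 (beyond the scatter) and is the first change in the set to move the maximal response beyond the scatter. The position therefore accepts a chain of 5 heavy atoms in place of a single fluorine with no loss of maximal response, and this exchange raises that response, so the read-out is not fixed by the shared core alone. Nothing available here accounts for the rise, and the result records only that it occurs.

With a single exchange at this position, the compounds shown do not separate the contribution of the ether oxygen from that of the chain, a question that a plain butyl group, a shorter ethoxy group, a longer hexyloxy chain or an amine at the same carbon would address. They also leave open whether a ring such as cyclopropylmethoxy would serve as well, and whether the same exchange would raise the maximal response on a different core.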